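Cyclopentylsulfanyl in place of pentyloxy: expected cytotoxicity

The compounds below may be only part of what the source reports. "The series", "measured", "known", "first", "only" and "open" are said of these compounds alone.

Measured compounds:
- Compound 1 `CCCOc1nc(N)nc2c1ncn2/C=C1/CC1(CO)CO` gives > 20000 nM in an ADME assay on Akata cells (Homo sapiens) for cytotoxicity, with a stated time of 7 days (a higher number here means that more compound is tolerated, a lower number that less compound is tolerated), a limit of the assay.
- Compound 2 `CCCCCOc1nc(N)nc2c1ncn2/C=C1/CC1(CO)CO` gives > 20000 nM in this assay, also a limit.
- Compound 3 `Nc1nc(NC2CCCC2)c2ncn(/C=C3/CC3(CO)CO)c2n1` gives > 20000 nM in this assay, again a limit.

Compound 2 therefore stands at the limit of > 20000 nM in this assay, at which 3 of the 3 values shown sit, with no number of its own. Every measured step is unreadable for the same reason: a step that the two limits leave unreadable from compound 1 to compound 2, a step that the two limits leave unreadable from compound 1 to compound 3 and a step that the two limits leave unreadable from compound 2 to compound 3. Compound 4 `Nc1nc(SC2CCCC2)c2ncn(/C=C3/CC3(CO)CO)c2n1` differs from compound 2 by cyclopentylsulfanyl in place of pentyloxy on an aromatic carbon. The step that the two limits leave unreadable from compound 2 to compound 3, the one closest in kind, gives no size in either direction, so no step beyond the scatter is expected in this assay, and the estimated step of a number no higher from compound 2 to compound 4 (the limit leaves the size open) reflects that. Compound 4 is expected at 20000 nM, within 10000 nM to 40000 nM, most likely again only as a limit.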

Compound 4, half-maximal cytotoxic concentration: > 20000 nM
Compound 4 gave a limit, no number (the forecaster's own chance of this, stated with the estimate: 85%); the middle value lies on the limit itself.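

Compound 1, compound 2, compound 3 and compound 4 all stop at a limit of the assay, so no step among them can be read: the limit of > 20000 nM in this assay, at which 4 of the 4 values shown sit.

As far as these compounds go, whether propoxy, pentyloxy, cyclopentylamino and cyclopentylsulfanyl differ at all in this assay stays open.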